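Methylsulfanyl for aminoamino on the shared core

The compounds below may be only part of what the source reports. "The series", "measured", "known", "first", "only" and "open" are said of these compounds alone.

- compound 1 `CSc1nc(-c2ccccc2O)c(C#N)c(=O)n1C` gives 44 ug/mL
- compound 2 `Cn1c(NN)nc(-c2ccccc2Cl)c(C#N)c1=O` gives 57 ug/mL

In a functional assay on microsomes for inhibition, with a stated time of 1 h (a higher number here means a weaker inhibitor, a lower number a stronger inhibitor), compound 2 at 57 ug/mL stands within the usual scatter of compound 1 at 44 ug/mL. Compound 3 `CSc1nc(-c2ccccc2Cl)c(C#N)c(=O)n1C`, not yet measured, has methylsulfanyl in place of aminoamino on an aromatic carbon, para to a cyano group: methylsulfanyl in place of aminoamino on an aromatic carbon. Within the data shown here, no measured pair isolates this change, so no shift beyond the scatter is expected in this assay. Compound 1, which also carries methylsulfanyl, gives 44 ug/mL. The expected change is a 1.1-fold lower number from compound 2 to compound 3 (0.06 log units; within the scatter). For compound 3 the estimated value is 50 ug/mL, with an expected range from 20 ug/mL to 120 ug/mL.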

Compound 3, half-maximal inhibitory concentration: 72 ug/mL
Compound 3: middle estimate off by 1.4-fold (0.16 log units), on the low side, and the stated range covers the measured number.
By their numbers in this assay, from the lowest: compounds 1, 2 and 3 (each within the scatter of the next).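

In this assay, methylsulfanyl in place of aminoamino, on the aromatic carbon para to a cyano group, now stands isolated in one pair and gives a 1.3-fold higher number from compound 2 to compound 3 (0.10 log units; within the scatter). The shared core therefore takes either group at this position with no shift beyond the scatter, even though the two groups differ in their counted hydrogen-bond donors. Chloro in place of hydroxy on an aromatic carbon, with methylsulfanyl held, gives a 1.6-fold higher number from compound 1 to compound 3 (0.21 log units; within the scatter). Nothing measured here offers an explanation for these results.

Still open, going by these compounds, is whether a morpholine or a longer chain such as butylsulfanyl on this carbon would move the number beyond the scatter. Also open, on these data alone, is how a methoxy group in place of the chloro would read.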